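Replacing benzamido with phenoxy: notes on compound 4

The compounds below may be only part of what the source reports. "The series", "measured", "known", "first", "only" and "open" are said of these compounds alone.

Measured so far in a functional assay on Ramos cells (Homo sapiens) for antiproliferative activity; a lower number here means a stronger inhibitor, a higher number a weaker inhibitor
- compound 1 `Nc1ncnc2c1c(-c1ccc(NC(=O)c3ccccc3)cc1)cn2[C@H]1CCN(C[C@@H]2CO2)C1` gives 2250 nM
- compound 2 `Nc1ncnc2c1c(-c1ccc(C(=O)Nc3ccc(Oc4ccccc4)cc3)cc1)cn2[C@H]1CCN(C[C@@H]2CO2)C1` gives 3630 nM
- compound 3 `Nc1ncnc2c1c(-c1cc3ccccc3o1)cn2[C@H]1CCN(C[C@@H]2CO2)C1` gives 6740 nM

Compound 1 and compound 2 lie within the scatter of each other, while compound 3 carries a higher number than compound 1, beyond the scatter. Of the three values, that of compound 1 is therefore matched only by compound 2.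

The next compound is compound 4 `Nc1ncnc2c1c(-c1ccc(Oc3ccccc3)cc1)cn2[C@H]1CCN(C[C@@H]2CO2)C1`, which has phenoxy in place of benzamido on an aromatic carbon, para to a large group. The counted difference from compound 1 is phenoxy in place of benzamido on an aromatic carbon and the shared core stays unchanged.

Among the compounds with values here, no measured pair differing in one place is available, so the size of this step in this assay cannot be read directly. Compound 2 also carries a phenoxy group and gives 3630 nM as its value, so no step beyond the scatter is expected, in either direction. The estimated step of a 1.1-fold lower number from compound 1 to compound 4 (0.05 log units; within the scatter) is expected to stay within the scatter. For compound 4 the expected value is 2000 nM with an estimated range of 600 nM to 7000 nM in this assay.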

Compound 4, half-maximal inhibitory concentration: 6710 nM
Compound 4: middle estimate off by 3.4-fold (0.53 log units), on the low side; the measured number falls inside the stated range.
By their numbers in this assay, from the lowest: compounds 1, 2, 4 and 3 (each within the scatter of the next, the first and the last beyond it).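

In this assay, within the data shown here, phenoxy in place of benzamido on an aromatic carbon, para to a large group, gives a 3.0-fold higher number from compound 1 to compound 4 (0.47 log units; beyond the scatter), the first step that can be read directly. Both groups carry a six-membered aromatic ring of carbon only, so keeping such a ring at this position does not by itself preserve the number of compound 1; the change also removes the amide hydrogen and the carbonyl. Nothing available explains this step.

This single step cannot separate the contribution of the amide hydrogen from that of the carbonyl, or either from the change in the group's size. On these data alone, it also remains open how an amine, a carboxylic acid or a longer chain on this aromatic carbon would compare with benzamido.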